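Lengthening an Alkylthio Chain on a Nucleoside Platelet Inhibitor

This account rests on a few compounds, and the source may have more. Where it says the series, first, only, none or still open, it means among the compounds named here.

The measurements come from a functional assay on a cell-free system (Platelet, plasma, Homo sapiens) for inhibition, with stated times of 1 min and 3 min; on this read-out higher numbers stand for weaker inhibition and lower numbers for stronger inhibition. Compound 1 `CCSc1nc(NC(C)c2ccccc2)c2ncn([C@@H]3O[C@H](CO)[C@@H](O)[C@H]3O)c2n1` sets the only firm reference point: in this assay compound 1 gives 197000 nM, a weak result. Compound 2 `CCSc1nc(NCc2ccc(OC)cc2)c2ncn([C@@H]3O[C@H](CO)[C@@H](O)[C@H]3O)c2n1` shares the same sugar-bearing core but carries a different substituent on its amine; for compound 2 the outcome in this assay is "not determined" (no result reported), so no number anchors it. Compound 3 `CCCCCCNc1nc(SCC)nc2c1ncn2[C@@H]1O[C@H](CO)[C@@H](O)[C@H]1O`, with a hexyl chain on the amine, likewise returns "not determined" (no result reported) in this assay.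

Compound 4 `CCCSc1nc(NCc2ccc(OC)cc2)c2ncn([C@@H]3O[C@H](CO)[C@@H](O)[C@H]3O)c2n1` differs from compound 2 in one place: methyl in place of hydrogen on a saturated chain carbon, two bonds along the chain from a sulfur. Among the measured compounds shown here, nothing measured here shows what such a change does, since no pair of measured compounds differs in this way. With compound 1 as the nearest point of comparison, the outcome for compound 4 is expected to stay weak, and no shift beyond the usual scatter in either direction is assumed for the step from compound 2. Compound 4 is therefore estimated at 120000 nM in this assay, within a range of 20000 nM to 700000 nM.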

Compound 4, half-maximal inhibitory concentration: 181000 nM
Compound 4: middle estimate off by 1.5-fold (0.18 log units), on the low side; the measured number falls inside the stated range.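

In this assay, among the compounds shown here, compound 2 carries no single number, and no step from it to compound 4 can be read. The compounds shown leave open whether going from ethylsulfanyl to propylsulfanyl changes inhibition at all. No evidence here bears on this result.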